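Triazole aryl swap: methylphenyl to tert-butylphenyl

A few compounds are considered here, and "the series" means these few. Any claim that something is new, unique, unknown or untested is made for them only; others in the source may bear on it.

This account follows a series built on one shared terpenoid core that ends in a triazole ring. Compound 1 `C/C(=C\CC/C(C)=C/CC[C@@H]1[C@@]2(C)CCC(=O)C(C)(C)[C@H]2CC[C@@]1(C)O)CC/C=C(\C)C(=O)OCc1cn(C[C@@H]2O[C@H](n3ccc(=O)[nH]c3=O)C[C@H]2O)nn1` and compound 3 `C/C(=C\CC/C(C)=C/CC[C@@H]1[C@@]2(C)CCC(=O)C(C)(C)[C@H]2CC[C@@]1(C)O)CC/C=C(\C)C(=O)OCc1cn(C[C@@H]2O[C@H](n3ccc(=O)[nH]c3=O)[C@H]3OC(C)(C)O[C@H]32)nn1` carry nucleoside fragments on the aromatic nitrogen of that ring; in a functional assay on A549 cells (Homo sapiens) for antiproliferative activity, read by MTT assay, with a stated time of 48 h (a lower number here means a stronger inhibitor, a higher number a weaker inhibitor), compound 1 gives 28100 nM, and compound 3 gives 15300 nM. Compound 2 `C/C(=C\CC/C(C)=C/CC[C@@H]1[C@@]2(C)CCC(=O)C(C)(C)[C@H]2CC[C@@]1(C)O)CC/C=C(\C)C(=O)OCc1cn(-c2ccccc2C)nn1` carries a 2-methylphenyl group there instead. In this assay compound 2 reaches only the limit of the assay, > 150000 nM, so no number is known for it. Among the three values shown, compound 2 is the one that sits at this limit (the limit of > 150000 nM in this assay, at which 1 of the 3 values shown sits). Compound 4 `C/C(=C\CC/C(C)=C/CC[C@@H]1[C@@]2(C)CCC(=O)C(C)(C)[C@H]2CC[C@@]1(C)O)CC/C=C(\C)C(=O)OCc1cn(-c2ccc(C(C)(C)C)cc2)nn1` differs from compound 2 in a single place: 4-(tert-butyl)phenyl in place of 2-methylphenyl on an aromatic nitrogen. Going by the values given here, no measured pair isolates this change, so its size has to be judged from the position of compound 2 alone. The step is expected to be small and without a clear direction beyond the scatter, a number no higher from compound 2 to compound 4 (the limit leaves the size open). Compound 4 is therefore estimated at 150000 nM, with a range from 60000 nM to 400000 nM, and a report of only a limit again is considered likely.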

Compound 4, half-maximal inhibitory concentration: > 150000 nM
Compound 4: a limit, no number; the forecaster's own chance of this, stated with the estimate: 60%; the middle value lies on the limit itself.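

In this assay compound 4 gives > 150000 nM, a limit and not a number. Going by these compounds alone, compound 2 also stands at a limit, so no step between compound 2 and compound 4 can be read. The compounds shown leave open what actual values compound 2 and compound 4 have, and how the 2-methylphenyl and 4-(tert-butyl)phenyl groups compare.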